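The source may hold more compounds than are shown below. What is called first, only, known or untested is meant among the compounds shown, and "the series" means these compounds.

Working notes on the dithiol amide series in a functional assay on HO8910 cells (Homo sapiens) for inhibition, read by MTT assay, with a stated time of 24 h, tested at 0.1 ug/mL; on this read-out lower numbers stand for less inhibition of growth and higher numbers for more inhibition of growth at the one concentration tested.

Compound 1 `O=C(CCCCC(S)CCS)Nc1ccccc1` gives 7.37% in this assay. Among the measured compounds shown here, compound 2 `O=C(CCCCC(S)CCS)Nc1ccc(Cl)cc1` differs from it by chloro in place of hydrogen on an aromatic carbon and gives 1.04%; the step of a number 6.3 percentage points lower from compound 1 to compound 2 (within the scatter) is the only measured pair that differs in one place. Compound 3 `O=C(CCCCC(S)CCS)Nc1ccccn1` carries a different core, (pyridin-2-yl in place of phenyl on an amide-type nitrogen), and in this assay compound 3 is reported as "not active" (no number reported), with no number attached.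

Compound 4 `O=C(CCCCC(S)CCS)Nc1ccc(Cl)cn1` is not yet measured. It stands to compound 3 as compound 2 stands to compound 1: chloro in place of hydrogen on an aromatic carbon. The change is the same kind of change as that from compound 1 to compound 2, not the same one, since the surrounding place differs: in compound 2 the chloro enters a six-membered aromatic ring of carbon only, whereas in compound 4 it enters a six-membered aromatic ring with 1 nitrogen, two atoms from the ring nitrogen. Both places are para to a large group.

Because the step of a number 6.3 percentage points lower from compound 1 to compound 2 (within the scatter) lies within the scatter, the expected step from compound 3 to compound 4 is small, and since compound 3 has no number, its value is expected to stay low. Compound 4 is estimated at 3%, expected between 0% and 12%.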

Compound 4, percent growth inhibition at one concentration: 2.65%
Estimate against measurement, compound 4: 0.4 percentage points above; low and high end bracket the measured number.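

Among the compounds shown here, compound 4 gives 2.65% and compound 3 is reported as "not active" (no number reported), so no step from compound 3 to compound 4 can be read. The compounds shown leave open whether chloro in place of hydrogen on the ring with nitrogen changes growth inhibition at all. Nothing at hand bears on this result.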